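Replacing 3-chlorophenyl in compound 2

The compounds below may be only part of what the source reports. "The series", "measured", "known", "first", "only" and "open" are said of these compounds alone.

Measured so far in a functional assay on SGC-7901 cells (Homo sapiens) for antiproliferative activity, read by MTT assay, with a stated time of 24 h; a lower number here means a stronger inhibitor, a higher number a weaker inhibitor:
- compound 1 (`O=C(NNc1ccccc1Cl)c1ccc(NS(=O)(=O)c2cnc(O)nc2O)cc1`) gives 3630 nM
- compound 2 (`O=C(NNc1cccc(Cl)c1)c1ccccc1NS(=O)(=O)c1cnc(O)nc1O`) gives 10800 nM

Of these two numbers, compound 2 has the higher, and the gap down to compound 1 lies beyond the usual scatter, so compound 2 is the weaker inhibitor in this assay here. Compound 3 (`O=C(NNC(=O)c1ccccc1NS(=O)(=O)c1cnc(O)nc1O)c1ccccc1F`) is derived from compound 2 by placing (2-fluorophenyl)carbonyl in place of 3-chlorophenyl on an amine nitrogen and has not yet been measured. Among the measured compounds shown here, no measured pair differs in one place, so no measured step offers a guide to this change. With so little to go on, no step beyond the scatter is expected, and the estimated move is a 1.5-fold lower number from compound 2 to compound 3 (0.19 log units; within the scatter) in a slightly lower direction. For compound 3 the expected value is 7000 nM, with an estimated range from 2000 nM to 25000 nM in this measurement.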

Compound 3, half-maximal inhibitory concentration: > 20000 nM
Compound 3 was reported as a limit (the forecaster's own chance of this, stated with the estimate: 10%); middle value at least 2.8-fold (0.45 log units) from the limit.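

In this assay, the first change read at this amine nitrogen, (2-fluorophenyl)carbonyl in place of 3-chlorophenyl, gives an at least 1.8-fold higher number from compound 2 to compound 3 (0.26 log units; that floor lies within the scatter). What compound 3 gives is a limit and not a number: the limit of > 20000 nM in this assay, at which 1 of the 3 values shown sits. The change therefore brought no lower number at this position, though the floor of the step alone does not place compound 3 beyond the scatter from compound 2.

Compound 3 adds the carbonyl and swaps the halogen and its place on the ring in a single step, so the compounds shown do not separate these changes. Going by these compounds, how a plain benzoyl or an acetyl group on this nitrogen would compare with the 3-chlorophenyl of compound 2 remains open.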